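Adding a 4,4-difluoropiperidin-1-yl group to compound 1

A few compounds are considered here, and "the series" means these few. Any claim that something is new, unique, unknown or untested is made for them only; others in the source may bear on it.

In a physicochemical assay for solubility, read by HPLC, in phosphate buffer, at pH 6.5 (a lower number here means a less soluble compound, a higher number a more soluble compound), compound 1 `COC(=O)C1=C(C)NC(c2nccs2)=NC1(C)c1ccc(F)cc1` gives 22 ug/mL, the lowest of three numbers, against compound 2 `COC(=O)C1=C(C)NC(c2nccs2)=N[C@]1(C)c1ccc(F)cc1` at 178 ug/mL and compound 3 `COC(=O)C1=C(C)NC(c2nccs2)=NC1(C)c1ccc(F)c(F)c1` at 50 ug/mL. Compound 4 `COC(=O)C1=C(CN2CCC(F)(F)CC2)NC(c2nccs2)=NC1(C)c1ccc(F)cc1` differs from compound 1 by 4,4-difluoropiperidin-1-yl in place of hydrogen on a saturated chain carbon bound to a double-bonded ring carbon. Neither measured step touches that place. Compound 3 shows a 2.3-fold higher number from compound 1 to compound 3 (0.36 log units; beyond the scatter), with fluoro in place of hydrogen on an aromatic carbon. Compound 2 shows an 8.1-fold higher number from compound 1 to compound 2 (0.91 log units; beyond the scatter), which goes with the fact that one of compounds 1 and 2 is drawn with a defined configuration and the other without, at the place where they differ. Both steps are modest, so they suggest only a rough size and no direction, and a step beyond the scatter is not expected in this assay. The estimated change is a 1.4-fold higher number from compound 1 to compound 4 (0.13 log units; within the scatter). For compound 4 the expected value is 30 ug/mL, within an estimated range of 6 ug/mL to 140 ug/mL.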

Compound 4, solubility: < 1 ug/mL
Compound 4: a limit, no number; the forecaster's own chance of this, stated with the estimate: 5%; middle value at least 30-fold (1.47 log units) away from the limit.
By their numbers in this assay, from the lowest: compound 1; then compound 3; then compound 2. At a limit, below all of these: compound 4.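

In this assay, the saturated chain carbon bound to a double-bonded ring carbon is a place where a change matters greatly: 4,4-difluoropiperidin-1-yl there gives an at least 22-fold lower number from compound 1 to compound 4 (1.34 log units; beyond the scatter). This is the only large step shown, and it runs opposite to the two modest steps at other places. The reading for compound 4 is a limit of the assay, not a number: the limit of < 1 ug/mL in this assay, at which 1 of the 4 values shown sits.

The compounds shown leave open whether the ring or its two fluorine atoms goes with this fall. Plain piperidin-1-yl, morpholin-4-yl or a carboxylic acid at this place remains untested here.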